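From a methoxyphenyl to a carboxyphenyl at the limit

The source may hold more compounds than are shown below. What is called first, only, known or untested is meant among the compounds shown, and "the series" means these compounds.

Measured so far in a functional assay (plasma) for inhibition, with Oryctolagus cuniculus as the target; a lower number here means that less compound is needed, a higher number that more compound is needed for the effect:
Compound 1 `CCOC(=O)c1c(C)cc2cnn(-c3cccc(OC)c3)c(=O)c2c1C`: >= 50 uM (a limit)
Compound 2 `CCOC(=O)c1c(C)cc2cnn(-c3ccc(OC)c(OC)c3)c(=O)c2c1C`: >= 50 uM (a limit)

In this assay compound 1 gives >= 50 uM, which is a limit of the assay and not a number. Compound 1 therefore has no exact standing, and the same is true of compound 2, so the evidence comes down to this: the limit of >= 50 uM in this assay, at which 2 of the 2 values shown sit.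

Compound 3 `CCOC(=O)c1c(C)cc2cnn(-c3ccc(C(=O)O)cc3)c(=O)c2c1C` has not yet been measured. It carries 4-carboxyphenyl in place of 3-methoxyphenyl on an aromatic nitrogen of the core of compound 1 (4-carboxyphenyl in place of 3-methoxyphenyl on an aromatic nitrogen). Within the data shown here, the only measured step, a step that the two limits leave unreadable from compound 1 to compound 2, puts methoxy in place of hydrogen on an aromatic carbon of that same aryl group. It bears on the new change only loosely and offers no size to carry over. No step beyond the scatter in this assay can therefore be expected in either direction, and a further limit is the likeliest report. For compound 3 the expected value is 50 uM, with an estimated range from 15 uM to 150 uM. The estimate amounts to an expected a number no higher from compound 1 to compound 3 (the limit leaves the size open).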

Compound 3, concentration for half-maximal effect: >= 50 uM
Compound 3 ended at the assay's limit; the forecaster's own chance of this, stated with the estimate: 70%; the middle value sits exactly at the limit.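

Among these compounds, the change from compound 1 to compound 3 gives no step that can be read, because both results in this assay are limits of the assay and not numbers: the limit of >= 50 uM in this assay, at which 3 of the 3 values shown sit.

The compounds shown leave open how much compound any of these three needs for the effect, and whether swapping the aryl group on the shared core changes that amount at all.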